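A few compounds are considered here, and "the series" means these few. Any claim that something is new, unique, unknown or untested is made for them only; others in the source may bear on it.

Measured so far:
Compound 2 `ClCc1ccccc1Cn1cnc2c(Cl)nc(Cl)nc21` – in a functional assay on K562 cells (Homo sapiens) for cytotoxicity, read by sulforhodamine B assay, with a stated time of 48 h (a lower number here means a stronger inhibitor of growth, a higher number a weaker inhibitor of growth), compound 2 gives 150 nM
Compound 1 `ClCc1ccc(Cn2cnc3c(Cl)ncnc32)cc1` – in this assay compound 1 gives 2910 nM

Of these two numbers, compound 2 holds the lowest, and the gap from compound 2 up to compound 1 lies well beyond the usual scatter of this assay, so compound 2 is the stronger growth inhibitor of the pair. Compound 3 `ClCc1ccccc1Cn1cnc2c(Cl)ncnc21` is the next step from compound 2: the change is hydrogen in place of chloro on an aromatic carbon. For the measured compounds named here, no pair of measured compounds isolates this change; compound 1 differs from compound 2 in more than one place, so its higher number cannot be laid on the missing chloro alone. The step of a 4.0-fold higher number from compound 2 to compound 3 (0.60 log units; beyond the scatter) is expected to be a moderate rise, with the real possibility that it stays within the scatter. Compound 3 is estimated at 600 nM, within a range from 150 nM to 2500 nM.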

Compound 3, concentration for 50% growth inhibition: 1200 nM
Compound 3: middle estimate off by 2.0-fold (0.30 log units), on the low side; measured number inside the range.
By their numbers in this assay, from the lowest: compound 2; then compound 3; then compound 1.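

In this assay, for the compounds shown here, the pair of compound 2 and compound 3 isolates this change for the first time, with all else in the structure the same: putting hydrogen in place of the chloro on the aromatic carbon between two ring nitrogen atoms gives an 8.0-fold higher number from compound 2 to compound 3 (0.90 log units; beyond the scatter) and so a weaker inhibitor of growth. This chloro therefore makes a real difference to the number in this series, although that rests on a single pair. Nothing shown here explains why the number rises.

The compounds shown do not tell whether an amine, a methoxy group or a fluoro on this same carbon would give a number closer to that of the chloro or of the hydrogen. They also leave open whether adding a chloro at this carbon of compound 1 would produce a step of similar size.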